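Swapping Chloro for Nitro on the Aromatic Ring

This account rests on a few compounds, and the source may have more. Where it says the series, first, only, none or still open, it means among the compounds named here.

In a functional assay on OVCAR-3 cells (Homo sapiens) for inhibition, read by sulforhodamine B assay, with a stated time of 48 h (on this read-out lower numbers stand for stronger inhibition of growth and higher numbers for weaker inhibition of growth), compound 1 `CC1=CC[C@H](C(C)(C)NC(=S)N/N=C/c2ccccc2)CC1` gives 20600 nM. Compound 2 `CC1=CC[C@H](C(C)(C)NC(=S)N/N=C/c2cccc(Cl)c2)CC1` carries a chloro group on the aromatic ring where compound 1 has hydrogen; in this assay compound 2 gives 80500 nM. That change produced a 3.9-fold higher number from compound 1 to compound 2 (0.59 log units; beyond the scatter). For the measured compounds named here, compound 2 therefore stands highest of the two numbers measured so far, with compound 1 as its only neighbour.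

Compound 3 `CC1=CC[C@H](C(C)(C)NC(=S)N/N=C/c2cccc([N+](=O)[O-])c2)CC1` has not yet been measured. Compared with compound 2 it shows (nitro in place of chloro on an aromatic carbon). Going by the values given here, no measured step exchanges one aromatic substituent for another; the only step at this position is the one from compound 1 to compound 2, which was modest and raised the number. A second swap at the same place is therefore expected to move the number little, if at all. Compound 3 is expected to give about 90000 nM in this assay, within a range from 30000 nM to 270000 nM. The expected step of a 1.1-fold higher number from compound 2 to compound 3 (0.05 log units; within the scatter) is estimated to lie close to the scatter.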

Compound 3, concentration for total growth inhibition: > 100000 nM
Compound 3 was reported as a limit; the forecaster's own chance of this, stated with the estimate: 20%; middle value at least 1.1-fold (0.04 log units) away from the limit.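

For compound 3 the reading is a limit and not a number: the limit of > 100000 nM in this assay, at which 1 of the 3 values shown sits. Putting a nitro group on this aromatic carbon in place of hydrogen gives an at least 4.8-fold higher number from compound 1 to compound 3 (0.68 log units; beyond the scatter), so a second group at this position, after chloro, also goes with weaker inhibition of growth. Exchanging chloro for nitro gives an at least 1.2-fold higher number from compound 2 to compound 3 (0.09 log units; that floor lies within the scatter), a floor that leaves the true gap between these two groups unknown, whether small or large.

The compounds shown leave open whether a different group at this position, such as an amine or a carboxylic acid, would also raise the number. They also leave open whether compound 1, at 20600 nM, would stay the lowest of the series once such groups are included.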